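The source may report more compounds than this note shows. Statements on the series, on what has been measured and on what is new or still open speak of the compounds shown alone.

Of the compounds shown here, three built on one shared core have been tested in an ADME assay on Vero cells (Chlorocebus sabaeus) for cytotoxicity, read by neutral red uptake, tested at 98 ug/mL; a higher number here means a weaker effect of the compound at the concentration tested, a lower number a stronger effect. Compound 1 `O=C1CSC(c2ccc(Cl)cc2)N1CCN1CCCCC1` gives 74%, compound 2 `O=C1CSC(c2ccccc2Cl)N1CCN1CCCCC1` gives 94%, and compound 3 `COc1ccccc1C1SCC(=O)N1CCN1CCCCC1` gives 100%, the highest of the three numbers, though it sits within the scatter of compound 2 and beyond it only against compound 1. The step of a number 20 percentage points higher from compound 1 to compound 2 (beyond the scatter) was modest, while the step of a number 6 percentage points higher from compound 2 to compound 3 (within the scatter) stayed within the scatter. Compound 4 `O=C1CSC(c2ccccc2[N+](=O)[O-])N1CCN1CCCCC1` differs from compound 3 in one place: nitro in place of methoxy on an aromatic carbon. Going by the values given here, only the step from compound 2 to compound 3, a swap of one group on an aromatic carbon, bears on this change, and it stayed within the scatter. For compound 4, therefore, a step of a number 3 percentage points lower from compound 3 to compound 4 (within the scatter) is expected, none beyond the scatter. Compound 4 is estimated at 97% in this assay, with a range from 86% to 100%.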

Compound 4, a percentage reported as activity, at one concentration (the size of the read-out at that concentration, not a potency): 100%
For compound 4 the middle estimate is 3 percentage points below the measured one; the measured number falls inside the stated range.
By their numbers in this assay, from the lowest: compound 1; then compounds 2, 3 and 4 (each within the scatter of the next).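

Nitro in place of methoxy gives no change at the digits printed from compound 3 to compound 4 (within the scatter) and nitro in place of chloro gives a number 6 percentage points higher from compound 2 to compound 4 (within the scatter) on this aromatic carbon. Chloro, methoxy and nitro at this one position thus all give numbers within the scatter of each other, even though nitro brings more heavy atoms and hydrogen-bond acceptors than methoxy. No measurement here explains this result. Going by these compounds, what an amine or a carboxylic acid on this aromatic carbon would give stays open. So does whether nitro would give the same number at the ring position that chloro holds in compound 1.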